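A Methyl Group on the Benzyl Ring of Compound 1

A few compounds are considered here, and "the series" means these few. Any claim that something is new, unique, unknown or untested is made for them only; others in the source may bear on it.

Measured so far in a functional assay on FM3A cells (Mus musculus) for cytotoxicity, read by cell counting, with a stated time of 2 days; a higher number here means a weaker inhibitor, a lower number a stronger inhibitor:
- compound 1 `Nc1ccc(/C=C2\SC(=O)N(Cc3ccccc3)C2=O)cc1` gives 24000 nM
- compound 2 `C=C(Br)C(=O)Nc1ccc(/C=C2\SC(=O)N(Cc3ccccc3)C2=O)cc1` gives 3000 nM
- compound 3 `C=C(Br)C(=O)Nc1ccc(/C=C2\SC(=O)N(Cc3ccc(F)cc3)C2=O)cc1` gives 4600 nM

Compound 1 has the highest number of the three, so it is the weakest inhibitor here. Compound 2 lies well below it, by an 8.0-fold lower number from compound 1 to compound 2 (0.90 log units; beyond the scatter), after a (1-bromoethenyl)carbonyl replaced hydrogen on a nitrogen on an aromatic ring. Compound 3 carries the same acyl group and sits close to compound 2.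

Compound 4 `Cc1ccc(CN2C(=O)S/C(=C\c3ccc(N)cc3)C2=O)cc1` is compound 1 with one change: methyl in place of hydrogen on an aromatic carbon. It keeps the free aromatic amine of compound 1 and alters only the benzyl ring. Going by the values given here, the one measured step that bears on this ring is a 1.5-fold higher number from compound 2 to compound 3 (0.19 log units; within the scatter), which stayed within the scatter. A small substituent on this ring therefore seems to move the number little, so the step from compound 1 to compound 4 is expected to be no change at the digits printed from compound 1 to compound 4 (within the scatter), not clearly beyond the scatter in either direction. Compound 4 is accordingly expected to give about 24000 nM, within the range 10000 nM to 55000 nM, in this assay.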

Compound 4, half-maximal inhibitory concentration: > 250000 nM
Compound 4: only a limit was reported (the forecaster's own chance of this, stated with the estimate: 5%); middle value at least 10-fold (1.01 log units) from the limit.
By their numbers in this assay, from the lowest: compounds 2 and 3 (each within the scatter of the next); then compound 1. At a limit, above all of these: compound 4.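

In this assay compound 4 stands at a limit and not at a number: the limit of > 250000 nM in this assay, at which 1 of the 4 values shown sits. Even so, the step is readable as an at least 10-fold higher number from compound 1 to compound 4 (1.01 log units; beyond the scatter), so changing phenyl to 4-methylphenyl, a single added carbon, is enough to make a clear difference when the free aromatic amine of compound 1 is present. The fluoro change, a 1.5-fold higher number from compound 2 to compound 3 (0.19 log units; within the scatter), stayed within the scatter, but it was made on compounds carrying the (1-bromoethenyl)carbonyl group, so that step does not show that this position tolerates every small change.

On these data alone, it remains open whether a chloro or a methoxy group at this place on compound 1 would behave like methyl or like fluoro. As far as these compounds go, it also remains open whether methyl has the same effect on compound 2, which carries the acylated nitrogen.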